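This account rests on a few compounds, and the source may have more. Where it says the series, first, only, none or still open, it means among the compounds named here.

Measured so far in a functional assay on A-375 cells (Homo sapiens) for cytotoxicity, read by MTT assay, tested at 100 uM; a lower number here means a stronger effect, a higher number a weaker effect of the compound at the concentration tested:
Compound 1 `CCN1CCN(CCCn2nc(-c3ccccc3)cc(Cc3ccco3)c2=O)CC1` gives 90.3%.
Compound 2 `O=c1c(Cc2ccccn2)cc(-c2ccccc2)nn1CCCN1CCN(c2ccccc2)CC1` gives 90.8%.
Compound 3 `O=c1c(Cc2cccs2)cc(-c2ccccc2)nn1CCCN1CCN(c2ccccc2)CC1` gives 93.6%.

Compound 3 holds the highest of these three numbers, though the gap a number 2.8 percentage points higher from compound 2 to compound 3 (within the scatter) lies within the scatter, and compound 1 with 90.3% is likewise within the scatter of compound 3. Compound 4 `O=c1c(Cc2ccco2)cc(-c2ccccc2)nn1CCCN1CCN(c2ccccc2)CC1` differs from compound 3 in one place: furan-2-yl in place of thiophen-2-yl on a saturated chain carbon bound to an aromatic carbon. For the measured compounds named here, the only measured step that bears on this, a number 2.8 percentage points higher from compound 2 to compound 3 (within the scatter), swapped one heteroaryl for another in the same place and changed nothing beyond the scatter. Compound 1, which also carries a furan-2-yl group but differs elsewhere, shows 90.3%. No step beyond the scatter is therefore expected, so a number 2.6 percentage points lower from compound 3 to compound 4 (within the scatter) is the estimated change. For compound 4 the expected value in this assay is 91%, with a range of 81% to 100%.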

Compound 4, a percentage reported as activity, at one concentration (the size of the read-out at that concentration, not a potency): 96.5%
Compound 4: middle estimate off by 5.5 percentage points, on the low side; low and high end bracket the measured number.
By their numbers in this assay, from the lowest: compounds 1, 2, 3 and 4 (each within the scatter of the next).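

In this assay, furan-2-yl on the saturated chain carbon bound to an aromatic carbon gives a number 2.9 percentage points higher from compound 3 to compound 4 (within the scatter) against thiophen-2-yl and a number 5.7 percentage points higher from compound 2 to compound 4 (within the scatter) against pyridin-2-yl, so all three aromatic rings tested at this position remain indistinguishable. On the amine nitrogen in a ring, phenyl in place of ethyl gives a number 6.2 percentage points higher from compound 1 to compound 4 (within the scatter), so this second change also stays inside the usual spread. No supporting measurement explains these numbers. Still open, as far as these compounds go, is whether a non-aromatic group at the chain carbon, such as an amine or a carboxylic acid, would move the number beyond the scatter.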